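Swapping a thiazole for a pyridine on the dienone arm

This account rests on a few compounds, and the source may have more. Where it says the series, first, only, none or still open, it means among the compounds named here.

Compound 3 `COc1cc(OC)c2c(=O)c(OCCCCOc3ccc(/C=C/C(=O)/C=C/c4scnc4C)cc3)c(-c3cc(OC)c(OC)c(OC)c3)oc2c1` is the weakest of the three measured compounds in a functional assay on SMMC-7721 cells (Homo sapiens) for antiproliferative activity, read by MTT assay, with a stated time of 48 h (a lower number here means a stronger inhibitor, a higher number a weaker inhibitor), where compound 3 gives 65100 nM. Its nearest neighbour is compound 2 `COc1cc(OC)c2c(=O)c(OCCCOc3ccccc3/C=C/C(=O)/C=C/c3cccc([N+](=O)[O-])c3)c(-c3cc(OC)c(OC)c(OC)c3)oc2c1`, which in this assay gives 9200 nM, and furthest from it is compound 1 `COc1cc(OC)c2c(=O)c(OCCCOc3ccccc3/C=C/C(=O)/C=C/c3ccccn3)c(-c3cc(OC)c(OC)c(OC)c3)oc2c1`, which gives 3180 nM. Compound 4 `COc1cc(OC)c2c(=O)c(OCCCCOc3ccc(/C=C/C(=O)/C=C/c4ccccn4)cc3)c(-c3cc(OC)c(OC)c(OC)c3)oc2c1` differs from compound 3 by pyridin-2-yl in place of 4-methyl-1,3-thiazol-5-yl on a double-bonded chain carbon bound to a double-bonded chain carbon. Among the measured compounds shown here, no measured step exchanges these two groups directly. For the measured compounds named here, the only single-point step that bears on this position is a 2.9-fold higher number from compound 1 to compound 2 (0.46 log units; beyond the scatter), which shows that a change of the aryl group at this place can shift the number by a modest amount in this assay. Compound 1, which carries the same pyridin-2-yl as compound 4, has the lowest number of the three, but compound 1 and compound 3 also differ elsewhere in the molecule, so their values cannot be read as one clean step. On this basis a modest move toward a lower number is expected for compound 4, estimated as a 2.6-fold lower number from compound 3 to compound 4 (0.42 log units; beyond the scatter), with the direction uncertain. Compound 4 is therefore expected to give about 25000 nM in this assay, within a range from 7000 nM to 80000 nM.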

Compound 4, half-maximal inhibitory concentration: 1690 nM
Compound 4: the middle estimate sits 15-fold (1.17 log units) above what was measured, and the stated range ends above it.
By their numbers in this assay, from the lowest: compounds 4 and 1 (each within the scatter of the next); then compound 2; then compound 3.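

With compound 3 and compound 4 the aryl group on the dienone arm is exchanged with nothing else changing, and in this assay this gives a 39-fold lower number from compound 3 to compound 4 (1.59 log units; beyond the scatter), a large step. Among the compounds shown here, the only earlier step at this place, a 2.9-fold higher number from compound 1 to compound 2 (0.46 log units; beyond the scatter), was modest, so the position proves far more responsive to the choice of aryl group than that pair could show. For the compounds shown here, in both pairs the compound carrying pyridin-2-yl has the lower number, against 3-nitrophenyl in one pair and 4-methyl-1,3-thiazol-5-yl in the other, although these two pairs differ in the rest of the molecule and each holds only one such exchange. Going by these compounds alone, nothing available here explains why this exchange moves the number so far.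

The compounds shown leave open whether the large step reflects something favourable in pyridin-2-yl or something unfavourable in 4-methyl-1,3-thiazol-5-yl, and a plain phenyl, a pyridin-4-yl or a thiazole without its methyl group at this place would help to separate those readings. Going by these compounds, it also remains open whether 4-methyl-1,3-thiazol-5-yl would cost as much on the rest of the molecule found in compound 1.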